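A Tert-Butyl Swap Carried Over to a Carbonyl Analogue

A few compounds are considered here, and "the series" means these few. Any claim that something is new, unique, unknown or untested is made for them only; others in the source may bear on it.

Compound 1, `COc1cc(N(Cc2nc3ccccc3[nH]2)S(=O)(=O)c2ccc(C)cc2)cc(OC)c1OC`, in a functional assay on MGC-803 cells (Homo sapiens) for inhibition, read by MTT assay, with a stated time of 48 h (a lower number here means a stronger inhibitor, a higher number a weaker inhibitor), gives 1020 nM.
Compound 2, `COc1cc(N(Cc2nc3ccccc3[nH]2)S(=O)(=O)c2ccc(C(C)(C)C)cc2)cc(OC)c1OC`, in this assay gives 24100 nM.
Compound 3, `COc1cc(N(Cc2nc3ccccc3[nH]2)C(=O)c2ccc(C)cc2)cc(OC)c1OC`, in this assay gives 30500 nM.

Compound 4, `COc1cc(N(Cc2nc3ccccc3[nH]2)C(=O)c2ccc(C(C)(C)C)cc2)cc(OC)c1OC`, has not been measured. It differs from compound 3 by tert-butyl in place of methyl on an aromatic carbon. The same change, (tert-butyl in place of methyl on an aromatic carbon), was seen once before, where it produced a 24-fold higher number from compound 1 to compound 2 (1.37 log units; beyond the scatter). The two cores differ by (4-methylphenyl)carbonyl in place of (4-methylphenyl)sulfonyl on a nitrogen on an aromatic ring, a change that on its own gave a 30-fold higher number from compound 1 to compound 3 (1.48 log units; beyond the scatter). Since compound 3 already sits at the weak end, the repeat is expected to be a smaller step, a 3.3-fold higher number from compound 3 to compound 4 (0.52 log units; beyond the scatter), an expectation that rests on the earlier step of a 24-fold higher number from compound 1 to compound 2 (1.37 log units; beyond the scatter). Compound 4 is estimated at 100000 nM. Its expected range runs from 30000 nM to 500000 nM, and there is a fair chance the assay returns only a limit.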

Compound 4, half-maximal inhibitory concentration: > 50000 nM
Compound 4 ended at the assay's limit; the forecaster's own chance of this, stated with the estimate: 40%; the middle value is on the limit's open side.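

In this assay compound 4 gives > 50000 nM, which is a limit of the assay and not a number. Tert-butyl in place of methyl on the core of compound 3 can therefore be read only as a floor, an at least 1.6-fold higher number from compound 3 to compound 4 (0.21 log units; that floor lies within the scatter), so this result does not show a loss beyond the scatter, nor does it rule one out. The result neither confirms that the change carries over from the core of compound 1 at the same size nor shows that it shrinks: the same change on two cores in this assay, a 24-fold higher number (1.37 log units; beyond the scatter) from compound 1 to compound 2 and an at least 1.6-fold higher number (0.21 log units; that floor lies within the scatter) from compound 3 to compound 4; the limit leaves it open whether they differ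

The compounds shown leave open how a different group on that aromatic carbon, such as an amine, a carboxylic acid or a longer chain, would fare on either core. For the compounds shown here, with only two cores, they also cannot say how the change behaves on a third.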